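The compounds below may be only part of what the source reports. "The series", "measured", "known", "first", "only" and "open" are said of these compounds alone.

Measured in a functional assay on DU-145 cells (Homo sapiens) for cytotoxicity, read by trypan blue exclusion, with a stated time of 96 h; a lower number here means a stronger inhibitor, a higher number a weaker inhibitor:

- compound 1 `COc1cc(OC)c(/C=C/S(=O)(=O)Nc2ccc(OC)c([N+](=O)[O-])c2)c(OC)c1`: 2500 nM
- compound 2 `COc1cc(OC)c(/C=C/S(=O)(=O)Nc2ccc(OC)c(NCC(=O)O)c2)c(OC)c1`: 400 nM

Of the two compounds measured in this assay, compound 2 has the lower number, at 400 nM, while compound 1 stands at 2500 nM. The next compound, compound 3 `COc1cc(OC)c(/C=C/S(=O)(=O)Nc2ccc(OC)c(NC(C)(C)C(=O)O)c2)c(OC)c1`, keeps the core of compound 2 and alters a single group: 1-carboxy-1-methylethyl in place of carboxymethyl on a nitrogen on an aromatic ring. In words, 1-carboxy-1-methylethyl stands in place of carboxymethyl on a nitrogen on an aromatic ring.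

Within the data shown here, only one measured step bears on this change, and it does so indirectly. The step is a 6.3-fold lower number from compound 1 to compound 2 (0.80 log units; beyond the scatter), a modest one that lies beyond the scatter. It replaced nitro with (carboxymethyl)amino, so it shows that the number can move with a change at this place. Among the measured compounds shown here, no measured pair tests the carboxymethyl to 1-carboxy-1-methylethyl exchange itself, which leaves the direction open. A step no larger than that modest one is expected, with a slight lean towards a higher number.

The expected change is a 1.4-fold higher number from compound 2 to compound 3 (0.14 log units; within the scatter). For compound 3 the estimated value is 550 nM, with an expected range from 170 nM to 1800 nM.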

Compound 3, half-maximal inhibitory concentration: 70 nM
Compound 3: middle estimate off by 7.9-fold (0.90 log units), on the high side; measured number outside the range, below it.
By their numbers in this assay, from the lowest: compound 3; then compound 2; then compound 1.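

In this assay, replacing carboxymethyl with 1-carboxy-1-methylethyl on the nitrogen gives a 5.7-fold lower number from compound 2 to compound 3 (0.76 log units; beyond the scatter) and places compound 3 lowest of the three, with both of its steps beyond the scatter. Among these compounds, the earlier step showed only that the number moves when nitro gives way to (carboxymethyl)amino on the aromatic carbon; this one shows that it moves again, in the same direction, when only the chain on that nitrogen changes while the carboxylic acid stays in the group. Counted from the nitro group, the whole replacement gives a 36-fold lower number from compound 1 to compound 3 (1.55 log units; beyond the scatter) and is a large step, although nothing measured on these compounds accounts for either change.

The compounds shown leave open which part of the added carbon count matters: a single methyl on the carbon bearing the carboxylic acid, a cyclopropane ring closed on that carbon, or a longer chain might each give a different number. As far as these compounds go, it also remains open what a methyl ester, a primary amide or a plain alkyl group would do in place of the carboxylic acid on this chain.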